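Series notes: from compound 2 to compound 3

A few compounds are considered here, and "the series" means these few. Any claim that something is new, unique, unknown or untested is made for them only; others in the source may bear on it.

Compound 1 `CCC(=O)c1ccc2c(c1)sc(=O)n2CCN(C)C` and compound 2 `CCC(=O)c1ccc2c(c1)sc(=O)n2CCN1CCCCC1` share the same core and differ only in the amine at the end of the chain. In a functional assay on the whole organism with Mus musculus as the target, in the maximal electroshock model (a lower number here means that less compound is needed, a higher number that more compound is needed for the effect), compound 1 gives 21.8 mg/kg, and compound 2 gives 8.7 mg/kg. Going by the values given here, the only measured step, a 2.5-fold lower number from compound 1 to compound 2 (0.40 log units; beyond the scatter), concerns that amine. Compound 2 therefore holds the lowest of the two numbers, set apart from compound 1 by a margin beyond the scatter.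

Compound 3 `CCCc1ccc2c(c1)sc(=O)n2CCN1CCCCC1` keeps the piperidin-1-yl of compound 2 and differs from it at one place: propyl in place of propanoyl on an aromatic carbon. Among the compounds with values here, no measured step touches this position, so the measurements give no guide to the size or direction of the change; the step from compound 1 to compound 2 was a different kind of change. The working expectation is no step beyond the scatter in this assay, with wide uncertainty. Compound 3 is estimated at 10 mg/kg, within 4 mg/kg to 30 mg/kg, an expected step of a 1.1-fold higher number from compound 2 to compound 3 (0.06 log units; within the scatter).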

Compound 3, dose for half-maximal effect: 7.6 mg/kg
Compound 3: middle estimate off by 1.3-fold (0.12 log units), on the high side; measured number inside the range.
By their numbers in this assay, from the lowest: compounds 3 and 2 (each within the scatter of the next); then compound 1.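

At this aromatic carbon, propyl in place of propanoyl gives a 1.1-fold lower number from compound 2 to compound 3 (0.06 log units; within the scatter) in this assay, so this pair gives no sign that the carbonyl of propanoyl, with its hydrogen-bond acceptor, is needed for the effect. The earlier compounds shown here showed a step only at the amine on the chain; this first reading at the aromatic carbon places compound 2 and compound 3 within the scatter of each other. Nothing at hand explains why the two groups read alike.

Still open, from the compounds shown here alone, is whether this holds for other groups on the same carbon, such as a butyl chain, a primary amine or a carboxylic acid. Also open, going by these compounds, is whether propyl reads the same when dimethylamino, as in compound 1, replaces piperidin-1-yl.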